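Fluoro for hydrogen on the aryl ring of compound 2

The source may hold more compounds than are shown below. What is called first, only, known or untested is meant among the compounds shown, and "the series" means these compounds.

Compound 2 `C[C@@H](O[C@H]1CC[C@]2(CC1)COC(C)(C)C2)c1nc(-c2ccc(CS(C)(=O)=O)c(F)c2)no1` and compound 1 `CC(O[C@H]1CC[C@]2(CC1)COC(C)(C)C2)c1nc(-c2ccc(CS(C)(=O)=O)c(F)c2)no1` share the same atoms and bonds and differ only in how their stereocentres are drawn. In a functional assay on HEK293 cells for agonist activity at Glucose-dependent insulinotropic receptor (Homo sapiens), read by cAMP accumulation, with a stated time of 30 min (a lower number here means that less compound is needed, a higher number that more compound is needed for the effect), compound 1 gives 44 nM, and compound 2 gives 27 nM. The step of a 1.6-fold lower number from compound 1 to compound 2 (0.21 log units; within the scatter) lies within the scatter, which fits with the fact that one of compounds 1 and 2 is drawn with a defined configuration and the other without, at the place where they differ. Of the two numbers, compound 2 stands at the lower one, with compound 1 within the scatter of it, so no order between them can be claimed.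

Compound 3 `C[C@@H](O[C@H]1CC[C@]2(CC1)COC(C)(C)C2)c1nc(-c2ccc(CS(C)(=O)=O)c(F)c2F)no1` differs from compound 2 by fluoro in place of hydrogen on an aromatic carbon. Among the compounds with values here, the only measured step, from compound 1 to compound 2, concerns the drawing of stereocentres and not the aromatic ring, so no measured step bears on placing a fluoro group at this position. The step of no change at the digits printed from compound 2 to compound 3 (within the scatter) is therefore expected to stay within the scatter, in no particular direction. Within the data shown here, compound 3 is estimated to give 27 nM in this assay, with a range from 9 nM to 80 nM that is set wide given that no measured step informs the change.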

Compound 3, half-maximal effective concentration: 301 nM
For compound 3 the middle estimate is 11-fold (1.05 log units) below the measured one, and the stated range ends below it.
By their numbers in this assay, from the lowest: compounds 2 and 1 (each within the scatter of the next); then compound 3.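

Fluoro in place of hydrogen, on an aromatic carbon ortho to a fluoro group and meta to a (methylsulfonyl)methyl group, brings an 11-fold higher number from compound 2 to compound 3 (1.05 log units; beyond the scatter) in this assay. The earlier pair differed only in how its stereocentres are drawn and stayed within the scatter, so this is the first change among the compounds shown to separate two numbers, and it shows that the number in this assay responds strongly to this aromatic position, even when only one heavy atom enters there. What is known about the compounds shown concerns only their stereocentres and offers no explanation for the size of this step.

The compounds shown leave open whether the rise in the number belongs to fluoro in particular or would also follow a chloro, methyl or methoxy group at the same carbon. They also leave open whether a step of this size would appear with hydrogen in place of the neighbouring fluoro group, or with the other stereocentre arrangements of the shared core.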